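A few compounds are considered here, and "the series" means these few. Any claim that something is new, unique, unknown or untested is made for them only; others in the source may bear on it.

Three compounds share one core and differ only in the group on one aromatic carbon: compound 1 (`CC(C)c1n[nH]c2c(NCc3ccc(-c4ccccn4)cc3)nc(NCCO)nc12`), compound 2 (`CC(C)c1n[nH]c2c(NCc3ccc(-c4ccccn4)cc3)nc(N3CCNCC3)nc12`) and compound 3 (`CC(C)c1n[nH]c2c(NCc3ccc(-c4ccccn4)cc3)nc(N[C@H]3CC[C@H](N)CC3)nc12`). In a functional assay on K562 cells (Homo sapiens) for cytotoxicity, read by fluorescence, with a stated time of 72 h (on this read-out lower numbers stand for stronger inhibition and higher numbers for weaker inhibition), compound 1 gives 38 nM and compound 2 gives 17 nM as its result. Compound 3 gives 593 nM and so stands highest of the three, which makes it the weakest so far.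

Compound 4 (`COc1ccc(CNc2nc(NCc3ccc(-c4ccccn4)cc3)c3[nH]nc(C(C)C)c3n2)cc1`) has not been measured. It keeps the core of compound 3 but carries 4-methoxybenzyl in place of 4-aminocyclohexyl on a nitrogen on an aromatic ring at the same place.

Within the data shown here, three measured steps bear on this change, and all of them alter the same place. Two are large: a 16-fold higher number from compound 1 to compound 3 (1.19 log units; beyond the scatter) and a 35-fold higher number from compound 2 to compound 3 (1.54 log units; beyond the scatter) show how far this position can move the number. The third, a 2.2-fold lower number from compound 1 to compound 2 (0.35 log units; beyond the scatter) is modest, so two rather different groups can give similar low numbers. Among the measured compounds shown here, none of the measured compounds has an aromatic ring at this place, so the data offer no direct precedent. Compound 3 sits at the high end, so a modest fall looks more likely than a further rise.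

The estimated step is a 2.4-fold lower number from compound 3 to compound 4 (0.38 log units; beyond the scatter) in this assay and remains a rough expectation. For compound 4 the expected value is 250 nM with an estimated range from 50 nM to 1200 nM in this read-out.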

Compound 4, half-maximal inhibitory concentration: 3950 nM
Beside the measured number, compound 4's estimate is 16-fold (1.20 log units) below it; measured number outside the range, above it.
By their numbers in this assay, from the lowest: compound 2; then compound 1; then compound 3; then compound 4.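

In this assay, putting 4-methoxybenzyl in place of 4-aminocyclohexyl on this nitrogen gives a 6.7-fold higher number from compound 3 to compound 4 (0.82 log units; beyond the scatter), so compound 3 did not mark the top of the range at this position, and compound 4 is now the weakest of the four. The comparisons with the two lowest numbers show how wide that range is: a 230-fold higher number from compound 2 to compound 4 (2.37 log units; beyond the scatter) for (4-methoxybenzyl)amino in place of piperazin-1-yl, and a 100-fold higher number from compound 1 to compound 4 (2.02 log units; beyond the scatter) for 4-methoxyphenyl in place of hydroxymethyl on the saturated chain carbon bound to that nitrogen. Among these compounds, the only group here with an aromatic ring at this place therefore gives the highest number, although no measurement explains why this change raises the number so far.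

With a single such compound, the effect of the aromatic ring cannot be separated from that of its methoxy group. A plain benzyl group, or a benzyl group carrying an amine instead of the methoxy, would help to tell these apart, while a 2-aminoethyl chain would show how an open-chain amine compares with the hydroxyl-bearing chain of compound 1.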